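The source may report more compounds than this note shows. Statements on the series, on what has been measured and on what is new or still open speak of the compounds shown alone.

Measured so far:
compound 1 `C=C[C@]1(C)C[C@@H](OC(=O)CNC(=O)Nc2ccc(OC)cc2)[C@]2(C)[C@H](C)CC[C@]3(CCC(=O)[C@H]32)[C@@H](C)[C@@H]1O`: > 10000 nM
compound 2 `C=C[C@]1(C)C[C@@H](OC(=O)CNC(=O)NC(=O)c2ccc(Br)cc2)[C@]2(C)[C@H](C)CC[C@]3(CCC(=O)[C@H]32)[C@@H](C)[C@@H]1O`: > 10000 nM
compound 3 `C=C[C@]1(C)C[C@@H](OC(=O)CNC(=O)NC(=O)c2cccc(F)c2)[C@]2(C)[C@H](C)CC[C@]3(CCC(=O)[C@H]32)[C@@H](C)[C@@H]1O`: > 10000 nM

All three were tested in a functional assay on HGC-27 cells (Homo sapiens) for inhibition, read by MTT assay, with a stated time of 72 h (on this read-out higher numbers stand for weaker inhibition and lower numbers for stronger inhibition), and each result is a limit rather than a number. In this assay, compound 1 gives only the limit > 10000 nM. Compound 2 and compound 3 also give only limits, and the whole measured set rests on (the limit of > 10000 nM in this assay, at which 3 of the 3 values shown sit).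

The next compound, compound 4 `C=C[C@]1(C)C[C@@H](OC(=O)CNC(=O)Nc2ccccc2Br)[C@]2(C)[C@H](C)CC[C@]3(CCC(=O)[C@H]32)[C@@H](C)[C@@H]1O`, shares the core of compound 1 and differs from it in one place: 2-bromophenyl in place of 4-methoxyphenyl on an amide-type nitrogen. This puts 2-bromophenyl in place of 4-methoxyphenyl on an amide-type nitrogen.

For the measured compounds named here, none of the measured steps makes this exchange. Two of them replace the same 4-methoxyphenyl with a different group: a step that the two limits leave unreadable from compound 1 to compound 2, and a step that the two limits leave unreadable from compound 1 to compound 3. The third is a step that the two limits leave unreadable from compound 2 to compound 3. None of these steps has a readable size, so they offer no measured basis for a shift in either direction. The expectation in this assay is therefore that the compound stays in the same inactive region. The expected step is a step that the limit leaves unreadable from compound 1 to compound 4. Compound 4 may well give only a limit again. For compound 4 the estimated value is 15000 nM, with an expected range from 5000 nM to 40000 nM.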

Compound 4, half-maximal inhibitory concentration: > 10000 nM
Compound 4: only a limit was reported; the forecaster's own chance of this, stated with the estimate: 75%; the middle value is on the limit's open side.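

In this assay compound 4 gives only the limit > 10000 nM, so its steps to compound 1, compound 2 and compound 3 cannot be read. The compounds shown leave open how strongly any of them inhibits and whether any exchange on the amide-type nitrogen shifts that, as the whole set rests on a single limit: the limit of > 10000 nM in this assay, at which 4 of the 4 values shown sit.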